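A few compounds are considered here, and "the series" means these few. Any claim that something is new, unique, unknown or untested is made for them only; others in the source may bear on it.

Measured in a functional assay on Bel-7402 cells (Homo sapiens) for cytotoxicity, read by MTT assay; on this read-out lower numbers stand for stronger inhibition and higher numbers for weaker inhibition:
Compound 1 `Cc1ccccc1Nc1nc(C)c(C(=O)/C=C/c2ccc(Cl)cc2)s1` gives only a limit, > 25000 nM.
Compound 2 `Cc1nc(Nc2ccccc2)sc1C(=O)/C=C/c1ccccc1Cl` gives only a limit, > 25000 nM.

Neither number is a true value; both are limits of this assay. Compound 2 thus stands at the limit of > 25000 nM in this assay, at which 2 of the 2 values shown sit, and nothing separates it from compound 1. Compound 3 `Cc1ccccc1Nc1nc(C)c(C(=O)/C=C/c2ccccc2Cl)s1` differs from compound 2 by methyl in place of hydrogen on an aromatic carbon. For the measured compounds named here, no step between measured compounds shows what this change does, so no shift beyond the scatter is expected in either direction. Compound 3 is expected to sit at the limit too, with a number no higher from compound 2 to compound 3 (the limit leaves the size open), giving an estimate of 25000 nM, between 10000 nM and 60000 nM.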

Compound 3, half-maximal inhibitory concentration: > 25000 nM
Compound 3: no number, only a limit (the forecaster's own chance of this, stated with the estimate: 75%); the middle value lies on the limit itself.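

For the compounds shown here, the values of compound 1, compound 2 and compound 3 in this assay are all limits, so no step between these compounds can be read: the limit of > 25000 nM in this assay, at which 3 of the 3 values shown sit. Left open is whether methyl in place of hydrogen, or 2-chlorophenyl in place of 4-chlorophenyl, changes the read-out at all.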